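The source may hold more compounds than are shown below. What is called first, only, known or untested is meant among the compounds shown, and "the series" means these compounds.

Of the compounds shown here, two have so far been measured in a functional assay on the whole organism (strain C57BL/6) for inhibition, with Mus musculus as the target, read by paw edema, with stated times of 1 h and 4 h, at a dose of 100 mg/kg by the oral route; a higher number here means more inhibition at the dose given (going by the name of the read-out), a lower number less inhibition. Compound 1, `CC(=O)Nc1ccc(Cc2noc(CCC(=O)O)n2)cc1`, gives 75.3% in this assay. Among the compounds with values here, compound 2, `COc1ccc(NC(=O)CCc2nc(Cc3ccc(NC(C)=O)cc3)no2)cc1`, gives 49.3% and stands as the lower of the two numbers; the one measured step, a number 26 percentage points lower from compound 1 to compound 2 (beyond the scatter), came from putting (4-methoxyphenyl)amino in place of hydroxy on a carbonyl carbon. Compound 3, `COc1ccc(NC(=O)CCc2nc(Cc3ccc(NC(C)=O)cc3)no2)cc1F`, has not yet been measured. It differs from compound 2 in a single place: fluoro in place of hydrogen on an aromatic carbon. Within the data shown here, no measured step concerns a change of this kind, as the only known step touches the carbonyl carbon and not the aromatic ring, so it offers no direct guide to the size or direction of this one. With nothing pointing either way, the change is expected to give a number 0.3 percentage points lower from compound 2 to compound 3 (within the scatter), a step within the scatter. Compound 3 is therefore estimated at 49% in this assay, within a range from 33% to 64%.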

Compound 3, a percentage reported as inhibition, in the whole organism at one dose (the size of the read-out at that dose, not a potency): 60.3%
Beside the measured number, compound 3's estimate is 11.3 percentage points below it; low and high end bracket the measured number.
By their numbers in this assay, from the lowest: compound 2; then compound 3; then compound 1.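

In this assay, fluoro in place of hydrogen on an aromatic carbon, ortho to a methoxy group, gives a number 11 percentage points higher from compound 2 to compound 3 (beyond the scatter). Within the data shown here, this shows that the 4-methoxyphenyl group can respond to the addition of a single atom at this position, which no earlier step could show. Replacing hydroxy on the carbonyl carbon with (3-fluoro-4-methoxyphenyl)amino still gives a number 15 percentage points lower from compound 1 to compound 3 (beyond the scatter), so the fluoro recovers only part of the loss seen with the unfluorinated amide. Nothing available explains why the number rises with fluoro.

As far as these compounds go, whether chloro or an amino group on the same carbon would move the number in the same direction remains open. It is also unknown whether the gain from fluoro would persist at other doses, since these numbers come from a single dose and are not a measure of potency.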